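Removing the N-methyl from the weaker mirror image

The source may report more compounds than this note shows. Statements on the series, on what has been measured and on what is new or still open speak of the compounds shown alone.

Compound 1 `COC(=O)[C@@H]1C[C@@H]2C[C@H]1N(C)C2`: < 4
Compound 2 `COC(=O)[C@H]1C[C@H]2C[C@@H]1N(C)C2`: 4.9

Both compounds were tested in a functional assay (ileum) with Cavia porcellus as the target; on this read-out higher numbers stand for higher potency (the scale is a negative logarithm) and lower numbers for lower potency. Compound 1 gives < 4, which is a limit and not a number. It therefore stands at the limit of < 4 in this assay, at which 1 of the 2 values shown sits. Among the measured compounds shown here, the only measured step is a number at least 0.90 log units higher from compound 1 to compound 2 (beyond the scatter), and it comes with the fact that compounds 1 and 2 differ only in the configuration as drawn.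

Compound 3 `COC(=O)[C@@H]1C[C@H]2CN[C@@H]1C2` keeps the configuration of compound 1 as drawn and differs from it in one place: hydrogen in place of methyl on an amine nitrogen in a ring. For the measured compounds named here, the measured step concerns configuration alone, so it gives no size for this change, and no measured pair covers the loss of the methyl. Compound 3 also stays on the side of compound 1, not of its mirror image, so the higher value of compound 2 is not expected to carry over. With no evidence for a direction, only a small change is expected, with a slight lean downward. The estimated step is a step that the limit leaves unreadable from compound 1 to compound 3. Compound 3 may well be reported only as a limit. For compound 3 the expected value is 3.8, with an estimated range from 3.3 to 4.4.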

Compound 3, negative logarithm of the half-maximal effective concentration: 6
The estimate for compound 3 lay 2.20 log units below the measured number; the whole stated range lies below it.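

Up to this point the only measured change was one of configuration: the fact that compounds 1 and 2 differ only in the configuration as drawn. Among the compounds shown here, compound 3 adds the first measured change on the amine nitrogen in a ring, and in this assay hydrogen in place of methyl there gives a number at least 2.00 log units higher from compound 1 to compound 3 (beyond the scatter), so in the configuration of compound 1 a methyl on this nitrogen is not needed for a measurable value. The value of compound 1, < 4, is a limit and not a number, so the step has a floor but no exact size: the limit of < 4 in this assay, at which 1 of the 3 values shown sits.

As far as these compounds go, it remains open whether hydrogen in place of methyl has a similar effect in the configuration of compound 2, and whether an ethyl group or a longer chain on the same nitrogen would fall nearer to compound 1 or to compound 3. From the compounds shown here alone, how much the methyl ester contributes is also open, for instance whether a carboxylic acid or an amide in its place on the core of compound 3 would keep the value of compound 3 (6).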